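Amide aryl variation on the shared core

The source may report more compounds than this note shows. Statements on the series, on what has been measured and on what is new or still open speak of the compounds shown alone.

Measured so far:
compound 1 `O=C(Nc1cccc(-c2oc3cc(-c4ccc(F)cc4)ccc3c(=O)c2O)c1)c1ccc(Cl)cc1` — 3670 nM
compound 2 `O=C(Nc1cccc(-c2oc3cc(-c4ccc(F)cc4)ccc3c(=O)c2O)c1)c1ccc(C(F)(F)F)cc1` — 17400 nM

In a functional assay on HeLa cells (Homo sapiens) for antiproliferative activity, read by CCK-8 assay, with a stated time of 72 h (a lower number here means a stronger inhibitor, a higher number a weaker inhibitor), compound 1 gives 3670 nM and compound 2 gives 17400 nM. Going by the values given here, the one measured step is a 4.7-fold higher number from compound 1 to compound 2 (0.68 log units; beyond the scatter). Among the compounds with values here, compound 2 therefore carries the higher of the two numbers, with compound 1 as its only neighbour across that step.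

Compound 3 `COc1cccc(C(=O)Nc2cccc(-c3oc4cc(-c5ccc(F)cc5)ccc4c(=O)c3O)c2)c1` is the next entry: 3-methoxyphenyl in place of 4-(trifluoromethyl)phenyl on a carbonyl carbon. Within the data shown here, the step of a 4.7-fold higher number from compound 1 to compound 2 (0.68 log units; beyond the scatter) is the only one that bears on this change; it alters the same aryl group on the carbonyl carbon and shows that such a swap can move the number beyond the scatter, but methoxy has not yet been tried, so the direction of the new step rests on no direct precedent. The expectation is that compound 3 moves back toward compound 1 rather than further, giving an estimated step of a 2.9-fold lower number from compound 2 to compound 3 (0.46 log units; beyond the scatter). Compound 3 is estimated at 6000 nM, with a range of 2000 nM to 20000 nM.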

Compound 3, half-maximal inhibitory concentration: 5650 nM
Compound 3: the middle estimate sits 1.1-fold (0.03 log units) above what was measured, and the stated range covers the measured number.
By their numbers in this assay, from the lowest: compounds 1 and 3 (each within the scatter of the next); then compound 2.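

In this assay, 3-methoxyphenyl in place of 4-(trifluoromethyl)phenyl on the carbonyl carbon gives a 3.1-fold lower number from compound 2 to compound 3 (0.49 log units; beyond the scatter) and so reverses most of the earlier rise. Against the 4-chlorophenyl amide, the same position gives a 1.5-fold higher number from compound 1 to compound 3 (0.19 log units; within the scatter) and the two aryl groups cannot be told apart in this assay, which leaves compound 2 as the only one of the three set apart by a step beyond the scatter. No measured evidence bears on the reason for these steps.

Compound 3 differs from compound 1 and compound 2 in both the substituent and its place on the ring, so the contribution of each stays unresolved. From the compounds shown here alone, how an amine or a carboxylic acid on this aryl ring would read in this assay also remains open.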